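The source may hold more compounds than are shown below. What is called first, only, known or untested is meant among the compounds shown, and "the series" means these compounds.

Measured so far in a functional assay on HepG2 cells (Homo sapiens) for antiproliferative activity, read by MTT assay, with a stated time of 48 h (on this read-out lower numbers stand for stronger inhibition and higher numbers for weaker inhibition), are two compounds
- compound 1 `COc1ccc(/C=C/c2cc(OC)cc(OC)c2/C=C/C(=O)c2ccc(F)cc2)cc1` gives 12.2 ug/mL
- compound 2 `COc1ccc(/C=C/c2cc(OC)cc(OC)c2/C=C/C(=O)c2ccccc2)cc1` gives 6.8 ug/mL

With only these two numbers available, compound 2 at 6.8 ug/mL stands within the scatter of compound 1 at 12.2 ug/mL and cannot be ranked apart from it. The next structure is compound 3 `COc1ccc(/C=C/c2cc(OC)cc(OC)c2/C=C/C(=O)c2ccc(C)cc2C)cc1`, which keeps the shared core of compound 2 and carries one change, (2,4-dimethylphenyl in place of phenyl on a carbonyl carbon). In words, this is 2,4-dimethylphenyl in place of phenyl on a carbonyl carbon. Among the compounds with values here, only one measured step bears on this, and only loosely. With hydrogen in place of fluoro on an aromatic carbon, the step is a 1.8-fold lower number from compound 1 to compound 2 (0.25 log units; within the scatter). Within the data shown here, no compound with a 2,4-dimethylphenyl group has been measured, so the data give no direct reading of this change and no firm direction. A step beyond the scatter in this assay is therefore not expected, and the expected step is a 1.2-fold higher number from compound 2 to compound 3 (0.07 log units; within the scatter). The estimated value for compound 3 is 8 ug/mL, with an expected range from 3.5 ug/mL to 18 ug/mL.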

Compound 3, half-maximal inhibitory concentration: 0.9 ug/mL
Estimate against measurement, compound 3: 8.9-fold (0.95 log units) above; measured number outside the range, below it.
By their numbers in this assay, from the lowest: compound 3; then compounds 2 and 1 (each within the scatter of the next).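

In this assay, the group on the carbonyl carbon proves able to move the read-out well beyond the scatter: 2,4-dimethylphenyl in place of phenyl gives a 7.6-fold lower number from compound 2 to compound 3 (0.88 log units; beyond the scatter), and 2,4-dimethylphenyl in place of 4-fluorophenyl gives a 14-fold lower number from compound 1 to compound 3 (1.13 log units; beyond the scatter). The earlier pair had shown only a 1.8-fold lower number from compound 1 to compound 2 (0.25 log units; within the scatter) for hydrogen in place of fluoro, so nothing up to that point had marked this aromatic ring as a place where a change could separate compounds; now compound 3 has the lowest number of the three, with its steps to both others printed as beyond the scatter. Nothing available here accounts for this drop in the number.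

The compounds shown leave open whether both methyl groups of 2,4-dimethylphenyl are needed or a single methyl group would do, and whether an ethyl group, a methoxy group or an amine on the same ring would give a similar number. All three compounds also share one core, so whether the same exchange would give a similar step on a different core remains an open question.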